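The compounds below may be only part of what the source reports. "The series", "measured", "known", "first", "only" and "open" are said of these compounds alone.

In a functional assay on MCF7 cells (Homo sapiens) for inhibition, read by colorimetric assay and MTT assay, with a stated time of 72 h (on this read-out lower numbers stand for stronger inhibition and higher numbers for weaker inhibition), three compounds sharing one core have been measured. Compound 1 `C=CCCCCOc1ccccc1-c1cnc(OCCC=C)n1C` gives 8000 nM, compound 2 `C=CCCCCOc1ccccc1-c1cnc(OCCCCC=C)n1C` gives 5000 nM, and compound 3 `C=CCCCCOc1ccccc1-c1cnc(OC)n1C` gives 98000 nM. Compound 3 thus has the highest number of the three, and it lies beyond the scatter of both others.

Compound 4 `C=CCCCCOc1ccccc1-c1cnc(OCCOCC=C)n1C` differs from compound 3 by one change: (allyloxy)methyl in place of hydrogen on a saturated chain carbon bound to an oxygen on an aromatic ring. In words, (allyloxy)methyl takes the place of hydrogen on a saturated chain carbon bound to an oxygen on an aromatic ring.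

Within the data shown here, two measured steps bear on this change, since both compare hydrogen with an unsaturated chain at that same place: a 12-fold higher number from compound 1 to compound 3 (1.09 log units; beyond the scatter) and a 20-fold higher number from compound 2 to compound 3 (1.29 log units; beyond the scatter). Both are large, and here they would be read in reverse, from hydrogen towards the longer chain. Among the measured compounds shown here, the single comparison between two such chains, a 1.6-fold lower number from compound 1 to compound 2 (0.20 log units; within the scatter), shows no separation. For the measured compounds named here, the entering (allyloxy)methyl also ends in a double bond, but unlike allyl and pent-4-en-1-yl it contains oxygen, and no measured compound tests that feature.

A large step towards a lower number is therefore expected in this assay, with more uncertainty than either measured step carries. The expected size is a 9.8-fold lower number from compound 3 to compound 4 (0.99 log units; beyond the scatter). Compound 4 is estimated at 10000 nM, within an expected range of 4000 nM to 30000 nM.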

Compound 4, half-maximal inhibitory concentration: 32000 nM
Estimate against measurement, compound 4: 3.2-fold (0.51 log units) below; the measured number lies above the stated range.
By their numbers in this assay, from the lowest: compounds 2 and 1 (each within the scatter of the next); then compound 4; then compound 3.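

In this assay the change from methoxy to 2-(allyloxy)ethoxy still lowers the number (a 3.1-fold lower number from compound 3 to compound 4 (0.49 log units; beyond the scatter)), so a chain ending in a double bond improves on hydrogen at this place even when it carries an oxygen, though only modestly. That chain does not match either all-carbon chain, since compound 4 reads higher than both (a 4.0-fold higher number from compound 1 to compound 4 (0.60 log units; beyond the scatter); a 6.4-fold higher number from compound 2 to compound 4 (0.81 log units; beyond the scatter)), and both of these steps lie beyond the scatter. Compounds 1 and 2 alone had shown no separation among chains at this place, whereas compound 4 shows that this place can tell such chains apart, so a terminal double bond does not by itself fix the number.

No supporting measurement explains the difference between the oxygen-bearing chain and the all-carbon chains. Going by these compounds, it remains open whether the oxygen itself or its location along the chain sets that difference, and how a saturated hexyl chain or a chain ending in an amine would read at this place in this assay.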